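A few compounds are considered here, and "the series" means these few. Any claim that something is new, unique, unknown or untested is made for them only; others in the source may bear on it.

Compound 1, with the structure `C=C1CC[C@@H]2[C@](C)(CO)[C@H](O)CC[C@@]2(C)[C@@H]1CCC1=CCOC1=O`, is a diterpenoid carrying a five-membered lactone at the end of a short side chain. In a functional assay on NP14 cells (Homo sapiens) for cytotoxicity, read by MTT assay, with a stated time of 48 h (on this read-out higher numbers stand for weaker inhibition and lower numbers for stronger inhibition), compound 1 gives only > 100000 nM, which is a limit of the assay rather than a number. On the numbers shown, compound 1 is therefore the one whose value is known least exactly, as the limit of > 100000 nM in this assay, at which 1 of the 3 values shown sits, records. Two other compounds from the same series do return numbers. Compound 2, with the structure `C=C1[C@H](O)C[C@@H]2[C@](C)(COC(=O)CC)[C@H](OC(=O)CC)CC[C@@]2(C)[C@@H]1CCc1ccoc1`, carries a furan ring and two ester groups and gives 27700 nM in this assay. Compound 3, with the structure `C=C1CC[C@H]2[C@@](C)(CCC(=O)[C@@]2(C)CO)[C@@H]1CCc1ccoc1`, also carries a furan ring but has a ketone in its core and gives 43200 nM in this assay.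

The compound still to be measured is compound 4, with the structure `C=C1CC[C@@H]2[C@](C)(CO)[C@H](O)CC[C@@]2(C)[C@@H]1CC(O)c1ccoc1`. It is made from compound 1 by the change (a group of 7 heavy atoms (5 carbon, 2 oxygen; one five-membered aromatic ring with 1 hetero atom) in place of a group of 7 heavy atoms (5 carbon, 2 oxygen; one five-membered non-aromatic ring with 1 hetero atom), on a saturated chain carbon bound to a saturated ring carbon). Among the measured compounds shown here, no directly comparable measured pair exists, so the size of the step can only be expected, not read off. Compound 2 and compound 3 both carry a furan and both return measurable numbers, which suggests that compound 4 will sit in the same region. The step from compound 1 to compound 4 is expected to be an at least 2.5-fold lower number from compound 1 to compound 4 (0.39 log units; beyond the scatter). Compound 4 is estimated to give 40000 nM in this assay, within a range from 15000 nM to 100000 nM.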

Compound 4, half-maximal inhibitory concentration: > 100000 nM
Compound 4 was reported as a limit (the forecaster's own chance of this, stated with the estimate: 30%); middle value at least 2.5-fold (0.39 log units) away from the limit.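

Compound 1 and compound 4 are both reported only as a limit of the assay, not as a number, so no step between them can be read: the limit of > 100000 nM in this assay, at which 2 of the 4 values shown sit.

The compounds shown leave open whether the (furan-3-yl)(hydroxy)methyl group of compound 4, in place of the five-membered non-aromatic ring group of compound 1, changes the result in this assay at all.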